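Working notes: from compound 2 to compound 3

This account rests on a few compounds, and the source may have more. Where it says the series, first, only, none or still open, it means among the compounds named here.

compound 1 `COc1cc(-c2cccc3nc(-c4ccccc4)oc23)cc(OC)c1OC` gives 3500 nM
compound 2 `COc1cc(-c2cccc3nc(-c4cccc(O)c4)oc23)cc(OC)c1OC` gives 5500 nM
compound 3 `COc1cc(-c2nc3cccc(-c4cc(OC)c(OC)c(OC)c4)c3o2)ccc1O` has no measurement yet

For the measured compounds named here, in a functional assay on U-251 cells (Homo sapiens) for antiproliferative activity, read by MTT assay, with a stated time of 48 h (a lower number here means a stronger inhibitor, a higher number a weaker inhibitor), compound 2 stands at 5500 nM and lies within the scatter of compound 1, the only other measured compound. The change to compound 3 is 4-hydroxy-3-methoxyphenyl in place of 3-hydroxyphenyl on an aromatic carbon and amounts to 4-hydroxy-3-methoxyphenyl in place of 3-hydroxyphenyl on an aromatic carbon. Going by the values given here, the one measured step bearing on it is a 1.6-fold higher number from compound 1 to compound 2 (0.20 log units; within the scatter) for hydroxy in place of hydrogen on an aromatic carbon. Among the compounds with values here, no measured step covers the methoxy that enters here, so the basis is thin. No step beyond the scatter is therefore expected in this assay. The estimated step is a 1.4-fold lower number from compound 2 to compound 3 (0.14 log units; within the scatter) and it stays within the scatter. Compound 3 is estimated at 4000 nM and a result from 1500 nM to 10000 nM would be expected here.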

Compound 3, half-maximal inhibitory concentration: 10300 nM
Estimate against measurement, compound 3: 2.6-fold (0.41 log units) below; the measured number lies above the stated range.
By their numbers in this assay, from the lowest: compounds 1, 2 and 3 (each within the scatter of the next, the first and the last beyond it).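

In this assay the exchange of 3-hydroxyphenyl for 4-hydroxy-3-methoxyphenyl gives a 1.9-fold higher number from compound 2 to compound 3 (0.27 log units; within the scatter) and so does not separate these two groups at this position. Set against plain phenyl, however, 4-hydroxy-3-methoxyphenyl gives a 2.9-fold higher number from compound 1 to compound 3 (0.47 log units; beyond the scatter) and this is the first step in the series to pass the scatter, a modest one toward weaker inhibition, so the aromatic carbon next to the ring nitrogen and the ring oxygen does respond to what is carried there. Nothing available accounts for this step.

Which part of 4-hydroxy-3-methoxyphenyl carries the step stays open, as the hydroxy and the methoxy cannot be told apart from compounds 1, 2 and 3. Also open, on these data alone, is how this position would answer to a phenyl bearing an amine or a carboxylic acid.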